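Exchanging one end group on compound 2

The source may hold more compounds than are shown below. What is called first, only, known or untested is meant among the compounds shown, and "the series" means these compounds.

Within the data shown here, in a functional assay on P388 cells (Mus musculus) for cytotoxicity, with a stated time of 4 days (a lower number here means that less compound is needed, a higher number that more compound is needed for the effect), two related compounds have numbers so far. Compound 1 (`CC1=CC(=O)CC(C)(C)[C@@]1(O)CC(=O)/C(C)=C/C=C/C(C)=C/C=C/C=C(C)/C=C/C=C(\C)C=C=C1C(C)(C)C[C@H](O)C[C@@]1(C)O`) gives 150 ug/mL. Compound 2 (`CC1=C(C#C/C(C)=C/C=C/C(C)=C/C=C/C=C(C)/C=C/C=C(\C)C(=O)C[C@@]23O[C@]2(C)C[C@@H](O)CC3(C)C)C(C)(C)C[C@H](O)C1`) gives 12.5 ug/mL, the lower of the two numbers, and the gap between them lies beyond the usual scatter. Compound 3 (`CC1=CC(=O)CC(C)(C)[C@@]1(O)CC(=O)/C(C)=C/C=C/C(C)=C/C=C/C=C(C)/C=C/C=C(\C)C#CC1=C(C)C[C@@H](O)CC1(C)C`) has not yet been measured. It departs from compound 2 in one place, on a saturated chain carbon bound to a carbonyl carbon: a group of 11 heavy atoms (9 carbon, 2 oxygen; one six-membered non-aromatic ring of carbon only) in place of a group of 11 heavy atoms (9 carbon, 2 oxygen; one three-membered non-aromatic ring with 1 hetero atom, one six-membered non-aromatic ring of carbon only), on a saturated chain carbon bound to a carbonyl carbon. The group with the three-membered ring leaves, and 1-hydroxy-2,6,6-trimethyl-4-oxocyclohex-2-en-1-yl enters. That entering group is also carried by compound 1, which reads 150 ug/mL, but compound 1 differs from compound 2 elsewhere too, so the data cannot show how much of the gap this group accounts for. A move to a higher number, part of the way towards compound 1, is therefore expected, and the estimate is a 3.2-fold higher number from compound 2 to compound 3 (0.51 log units; beyond the scatter). For compound 3 the expected value is 40 ug/mL, with an estimated range from 14 ug/mL to 120 ug/mL.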

Compound 3, concentration for half-maximal effect: 300 ug/mL
The estimate for compound 3 lay 7.5-fold (0.88 log units) below the measured number; measured number outside the range, above it.
By their numbers in this assay, from the lowest: compound 2; then compounds 1 and 3 (each within the scatter of the next).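

Swapping the group with the three-membered ring for 1-hydroxy-2,6,6-trimethyl-4-oxocyclohex-2-en-1-yl, on a saturated chain carbon bound to a carbonyl carbon, gives a 24-fold higher number from compound 2 to compound 3 (1.38 log units; beyond the scatter) in this assay and is the first change here confined to one place. Among these compounds, compound 1 carries the same entering group but differs from compound 2 elsewhere too, so only this step shows that the exchange alone moves the number strongly, and upwards. The two groups match in heavy atoms, hydrogen-bond donors and hydrogen-bond acceptors, so those counts do not separate them, and no measurement offered here explains the step.

From the compounds shown here alone, with only these two groups seen at this position, it remains open whether the three-membered ring, the ring carbonyl or another feature of the two groups carries the difference. A smaller group at the same place, such as a plain methyl, or a charged one, such as a carboxylic acid, would show whether the low number of compound 2 needs its full end group at all.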